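A few compounds are considered here, and "the series" means these few. Any claim that something is new, unique, unknown or untested is made for them only; others in the source may bear on it.

Of the compounds shown here, two have so far been measured in a functional assay on the whole organism for antagonist activity, with Mus musculus as the target; on this read-out lower numbers stand for an effect already at smaller amounts and higher numbers for an effect only at larger amounts of compound. In this assay, compound 1 `CCc1nccn1CC#CCN1CCCC1=O` gives 0.54 mg/kg, which shows that a low dose can be reached with a compound of this kind. Compound 2 `CC(=O)N(C)C(C)C#CCn1ccnc1` is reported as > 100 mg/kg, and this is a limit of the assay, not a number. Compound 2 thus stands at the limit of > 100 mg/kg in this assay, at which 1 of the 2 values shown sits.

Compound 3 `CC(=O)N(C)C(C)C#CCn1cncc1C` is compound 2 with methyl in place of hydrogen on an aromatic carbon, next to the ring atom that bears a large group: methyl in place of hydrogen on an aromatic carbon. Within the data shown here, no measured pair isolates a change of this type, so any expectation remains loose. The expectation for compound 3 starts from compound 2, whose > 100 mg/kg is a limit. A single added methyl is expected to bring at most a modest shift toward smaller doses in this assay, and another result reported only as a limit would be no surprise. The expected change is an at least 1.2-fold lower number from compound 2 to compound 3 (0.09 log units; that floor lies within the scatter). The estimate for compound 3 is 80 mg/kg, with an expected range from 20 mg/kg to 200 mg/kg.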

Compound 3, dose for half-maximal effect: 1.1 mg/kg
Estimate against measurement, compound 3: 73-fold (1.86 log units) above; the measured number lies below the stated range.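

In this assay, methyl in place of hydrogen on an aromatic carbon, next to the ring atom that bears a large group, gives an at least 90-fold lower number from compound 2 to compound 3 (1.95 log units; beyond the scatter), a step beyond the scatter. Among these compounds, this is the first pair that differs in one place only, and it shows that this single position can decide whether an effect appears at small doses or not even at the largest amounts reported. The true size of the step may be greater still, since the number for compound 2 is a limit of the assay and fixes only a floor for the step: the limit of > 100 mg/kg in this assay, at which 1 of the 3 values shown sits.

Going by these compounds, whether the step needs methyl specifically remains open, as does what a chlorine atom, a propyl chain or an amine would do at the same position. Also open, on these data alone, is whether methyl on another aromatic carbon of the ring would give a step of similar size, and the whole-organism read-out by itself cannot tell why this single carbon makes so large a difference.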